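Furan to hydroxymethoxyphenyl on the hydrazone carbon

A few compounds are considered here, and "the series" means these few. Any claim that something is new, unique, unknown or untested is made for them only; others in the source may bear on it.

Compound 3 `O=C(N/N=C/c1ccco1)c1cccc(S(=O)(=O)N2CCOCC2)c1` reaches only a limit in a functional assay on MGC-803 cells (Homo sapiens) for antiproliferative activity, read by MTT assay, with a stated time of 72 h (on this read-out higher numbers stand for weaker inhibition and lower numbers for stronger inhibition), reported as > 100000 nM. That limit is the limit of > 100000 nM in this assay, at which 1 of the 3 values shown sits. The change to compound 4 `COc1ccc(/C=N/NC(=O)c2cccc(S(=O)(=O)N3CCOCC3)c2)c(O)c1` is 2-hydroxy-4-methoxyphenyl in place of furan-2-yl on a carbon with a double bond to nitrogen. Among the measured compounds shown here, no measured step touches the furan itself; the closest comparison is compound 1 `C/C(=N\NC(=O)c1cccc(S(=O)(=O)N2CCOCC2)c1)c1ccccc1O` at 1220 nM against compound 2 `C/C(=N\NC(=O)c1cccc(S(=O)(=O)N2CCOCC2)c1)c1ccc(O)cc1` at 71400 nM, a change of a 59-fold higher number from compound 1 to compound 2 (1.77 log units; beyond the scatter), which shows that a 2-hydroxyphenyl group goes with a far lower number than a 4-hydroxyphenyl group. Compound 4 carries a 2-hydroxy substituent as well, though without the methyl present in compound 1. The expected step is therefore an at least 16-fold lower number from compound 3 to compound 4 (1.22 log units; beyond the scatter), toward a lower number. The estimate for compound 4 is 6000 nM, with a range from 1200 nM to 40000 nM.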

Compound 4, half-maximal inhibitory concentration: 2070 nM
Compound 4: the middle estimate sits 2.9-fold (0.46 log units) above what was measured, within the range that was stated.
By their numbers in this assay, from the lowest: compounds 1 and 4 (each within the scatter of the next); then compound 2. At a limit, above all of these: compound 3.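

Among the compounds shown here, the step for compound 3 to compound 4 is the first measured change of the furan-2-yl group on this carbon with a double bond to nitrogen: an at least 48-fold lower number from compound 3 to compound 4 (1.68 log units; beyond the scatter). It shows that the group at this place alone can bring the series from a limit to a measurable value in this assay. Its true size stays open, as compound 3 stands at a limit: the limit of > 100000 nM in this assay, at which 1 of the 4 values shown sits.

Going by these compounds, the hydroxy and methoxy groups enter together with the six-membered ring, so their separate shares remain unknown. On these data alone, how an amine or a carboxylic acid on that ring would read also remains open.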